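A Single Fluorine Added to Compound 1

This account rests on a few compounds, and the source may have more. Where it says the series, first, only, none or still open, it means among the compounds named here.

For the measured compounds named here, compound 1 `O=C(Nc1nc2ccc(F)cc2s1)c1cn(-c2ccccc2)nc1-c1ccccc1` is the only compound here with a number rather than a limit in a functional assay on HT-29 cells (Homo sapiens) for cytotoxicity, read by MTT assay, with a stated time of 72 h (a lower number here means a stronger inhibitor, a higher number a weaker inhibitor), where compound 1 gives 9800 nM. Compound 2 `COc1ccc2nc(NC(=O)c3cn(-c4ccccc4)nc3-c3ccccc3)sc2c1` differs from it by methoxy in place of fluoro on an aromatic carbon. In this assay compound 2 reaches only the limit of the assay, > 50000 nM. Going by the values given here, that step, an at least 5.1-fold higher number from compound 1 to compound 2 (0.70 log units; beyond the scatter), is the sole measured comparison, and it rests on (the limit of > 50000 nM in this assay, at which 1 of the 2 values shown sits).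

Compound 3 `O=C(Nc1nc2ccc(F)cc2s1)c1cn(-c2ccccc2)nc1-c1ccc(F)cc1` is compound 1 with one further change: fluoro in place of hydrogen on an aromatic carbon. Among the compounds with values here, the one measured step touches a different ring of the shared core, so no measured step bears directly on this change. With nothing pointing either way, the step from compound 1 to compound 3 is expected to stay within the usual scatter, as a 1.2-fold lower number from compound 1 to compound 3 (0.09 log units; within the scatter). Compound 3 is therefore estimated at 8000 nM in this assay, with a range of 3000 nM to 25000 nM.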

Compound 3, half-maximal inhibitory concentration: 4160 nM
The estimate for compound 3 lay 1.9-fold (0.28 log units) above the measured number; the measured number falls inside the stated range.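

In this assay the change from phenyl to 4-fluorophenyl gives a 2.4-fold lower number from compound 1 to compound 3 (0.37 log units; beyond the scatter) and so counts as a real, though modest, shift. For the compounds shown here, this is the first measured evidence on this ring of the shared core: a single fluorine, placed para to a large group, is enough to move the number. Going by these compounds alone, the only earlier step changed a different ring and ended at a limit of the assay, whereas this one moves towards a stronger inhibitor and gives two exact numbers to compare.

Nothing shown here explains why the added fluorine has this effect. As far as these compounds go, it also remains open whether chloro, an amine or a carboxylic acid at this same position would strengthen or weaken the compound further.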